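This account rests on a few compounds, and the source may have more. Where it says the series, first, only, none or still open, it means among the compounds named here.

Measured in an assay on cells for activation of probable G-protein coupled receptor 34 (Mus musculus), with a stated time of 1 h; a lower number here means a smaller maximal response, a higher number a larger maximal response:

Compound 1, `N[C@@H](COP(=O)(O)OCCCOC(=O)CCc1ccccc1OCc1cccc(Cc2ccccc2)c1)C(=O)O`: 0.077
Compound 2, `N[C@@H](COP(=O)(O)OCCCOC(=O)CCc1ccccc1OCc1cccc(Oc2ccc(Cl)c(Cl)c2)c1)C(=O)O`: 0.71
Compound 3, `N[C@@H](COP(=O)(O)OCCCOC(=O)CCc1ccccc1OCc1cccc(Oc2ccc(I)cc2)c1)C(=O)O`: 0.82

Of these three, compound 1 stands lowest: compound 2 sits a number 0.63 higher from compound 1 to compound 2 (beyond the scatter) and compound 3 sits a number 0.74 higher from compound 1 to compound 3 (beyond the scatter), both well beyond the scatter. Compound 4, `N#Cc1ccc(Oc2cccc(COc3ccccc3CCC(=O)OCCCOP(=O)(O)OC[C@H](N)C(=O)O)c2)cc1`, has not yet been measured in this assay. It differs from compound 1 in one place: 4-cyanophenoxy in place of benzyl on an aromatic carbon.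

Going by the values given here, two measured steps bear on this change, since both replace the same benzyl group with a phenoxy group carrying a substituent: the change to compound 2 gave a number 0.63 higher from compound 1 to compound 2 (beyond the scatter), and the change to compound 3 gave a number 0.74 higher from compound 1 to compound 3 (beyond the scatter). The two phenoxy groups themselves differ only modestly, with a number 0.11 higher from compound 2 to compound 3 (beyond the scatter). A third phenoxy group, here with a nitrile, is therefore expected to give a large step upward as well, estimated at a number 0.62 higher from compound 1 to compound 4 (beyond the scatter). For compound 4 the expected intrinsic activity is 0.7, with a range from 0.45 to 0.9.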

Compound 4, intrinsic activity: the largest response reached, as a fraction of the reference agonist's: 0.041
Estimate against measurement, compound 4: 0.66 above, outside the stated range (below it).
By their numbers in this assay, from the lowest: compounds 4 and 1 (each within the scatter of the next); then compound 2; then compound 3.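

In this assay, a phenoxy group in place of benzyl does not by itself bring a large maximal response: 4-cyanophenoxy in place of benzyl gives a number 0.036 lower from compound 1 to compound 4 (within the scatter). What sits on the outer ring therefore matters greatly at this position, with cyano in place of iodo giving a number 0.78 lower from compound 3 to compound 4 (beyond the scatter) and 4-cyanophenyl in place of 3,4-dichlorophenyl giving a number 0.67 lower from compound 2 to compound 4 (beyond the scatter). Nothing available explains why the nitrile-bearing compound parts so sharply from the two halogen-bearing ones.

As far as these compounds go, it remains open where plain phenoxy, with no substituent on its ring, would fall. From the compounds shown here alone, it is also open whether 4-methoxyphenoxy, 4-bromophenoxy or 4-aminophenoxy would follow compound 3 or compound 4, which would show how far the halogens stand apart from other groups here.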